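This account rests on a few compounds, and the source may have more. Where it says the series, first, only, none or still open, it means among the compounds named here.

Of the compounds shown here, two built on a shared core have so far been tested in a functional assay on FM3A cells (Mus musculus) for antiproliferative activity; a higher number here means a weaker inhibitor, a lower number a stronger inhibitor. Compound 1 `COc1ccc(-c2cc(N)c(C(=O)c3cc(OC)c(OC)c(OC)c3)s2)cc1OC` gives 72 nM in this assay. Among the measured compounds shown here, compound 2 `COc1cc(C(=O)c2sc(-c3ccccc3)cc2N)cc(OC)c1OC` gives 13 nM, the lowest of the two numbers, and the only step between them, a 5.5-fold lower number from compound 1 to compound 2 (0.74 log units; beyond the scatter), accompanies phenyl in place of 3,4-dimethoxyphenyl on an aromatic carbon. Compound 3 `COc1cc(C(=O)c2sc(-c3ccc(F)cc3)cc2N)cc(OC)c1OC` has not yet been measured. It differs from compound 2 by fluoro in place of hydrogen on an aromatic carbon.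

For the measured compounds named here, the one measured step replaced a group carrying two methoxy substituents with a bare phenyl, and its size was modest; it bears only loosely on the addition of a single fluorine to that same phenyl, so there is no direct guide from the data for this change. With a bare phenyl already giving the lowest number here, a small change such as this is expected to move the number little, most likely within the scatter in either direction. The step from compound 2 to compound 3 is therefore expected to be about a 1.2-fold higher number from compound 2 to compound 3 (0.06 log units; within the scatter). Compound 3 is estimated at 15 nM, within a range from 5 nM to 45 nM.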

Compound 3, half-maximal inhibitory concentration: 16 nM
Estimate against measurement, compound 3: 1.1-fold (0.03 log units) below; the range from low to high includes it.
By their numbers in this assay, from the lowest: compounds 2 and 3 (each within the scatter of the next); then compound 1.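

In this assay, adding a fluoro group to the phenyl ring of compound 2, para to a large group, gives a 1.2-fold higher number from compound 2 to compound 3 (0.09 log units; within the scatter), so this small addition leaves no change that can be told from ordinary scatter. The 3,4-dimethoxyphenyl group of compound 1 now stands against two different rings rather than one: alongside the earlier step to phenyl, there is a 4.5-fold lower number from compound 1 to compound 3 (0.65 log units; beyond the scatter), and among these three compounds none goes against the lower numbers for phenyl and 4-fluorophenyl. No independent measurement is available to explain these results.

The compounds shown leave open whether this tolerance extends beyond a single fluorine at this place, for instance to a chloro group, a dimethylamino group or a carboxylic acid, any of which would test the position far more sharply. From the compounds shown here alone, they also cannot separate the two methoxy groups of compound 1, so it remains unknown whether a single methoxy group at either place would go with a number like that of compound 1 or like those of compound 2 and compound 3.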